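The source may hold more compounds than are shown below. What is called first, only, known or untested is meant among the compounds shown, and "the series" means these compounds.

Measured in a functional assay on NCI-H460 cells (Homo sapiens) for cytotoxicity, read by sulforhodamine B assay, with a stated time of 3 days; on this read-out higher numbers stand for weaker inhibition and lower numbers for stronger inhibition:
- compound 1 `OCc1cn(Cc2cccc(F)c2)c2ccccc12`: 40 nM
- compound 2 `OCc1cn(Cc2cccc(Cl)c2)c2ccccc12`: 19 nM

Of these two, compound 1 has the higher number. Compound 3 `OCc1cn(Cc2cccc(F)c2)c2ccc(Cl)cc12` differs from compound 1 by chloro in place of hydrogen on an aromatic carbon. For the measured compounds named here, the only measured step is a 2.1-fold lower number from compound 1 to compound 2 (0.32 log units; beyond the scatter). It is modest, replaces fluoro rather than hydrogen and lies elsewhere on the structure, so it bears only loosely. A similarly modest shift toward a lower number in this assay is expected, written as an estimated 1.8-fold lower number from compound 1 to compound 3 (0.26 log units; within the scatter). For compound 3 the expected value is 22 nM, with an estimated range of 8 nM to 60 nM.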

Compound 3, half-maximal inhibitory concentration: 70 nM
Compound 3: middle estimate off by 3.2-fold (0.50 log units), on the low side; measured number above the stated range.
By their numbers in this assay, from the lowest: compound 2; then compounds 1 and 3 (each within the scatter of the next).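

On this aromatic carbon of the fused two-ring system, chloro in place of hydrogen gives no step beyond the scatter in this assay (a 1.8-fold higher number from compound 1 to compound 3 (0.24 log units; within the scatter)). The position therefore tolerates chloro in this one pair, and the lower number seen with chloro in place of fluoro at the other site does not recur here. No available data explain this result.

Still open, from the compounds shown here alone, is whether a larger group here, such as methoxy or an amine, would move the number beyond the scatter. Also open, going by these compounds, is whether chloro at other carbons of this ring behaves alike.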